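The compounds below may be only part of what the source reports. "The series", "measured", "known", "first", "only" and "open" are said of these compounds alone.

Measured compounds:
compound 1, `Cc1ccc(CS/C(=C/c2ccccc2F)C(=O)c2ccc(Cl)cc2)cc1`, 10000 nM in a functional assay on DU-145 cells (Homo sapiens) for inhibition, read by trypan blue exclusion, with a stated time of 96 h; a lower number here means a stronger inhibitor of growth, a higher number a weaker inhibitor of growth
compound 2, `Cc1ccc(CS/C(=C/c2cc([N+](=O)[O-])ccc2F)C(=O)c2ccc(Cl)cc2)cc1`, 1000 nM in this assay
compound 3, `Cc1ccc(CS/C(=C/c2ccccc2Br)C(=O)c2ccc(Cl)cc2)cc1`, 10000 nM in this assay

Compound 1 stands level with compound 3 at the digits shown, the two together giving the highest numbers of the three in this assay, and it lies furthest from compound 2, which shows a 10-fold lower number from compound 1 to compound 2 (1.00 log units; beyond the scatter). Compound 4, `Cc1ccc(CS/C(=C/c2ccccc2F)C(=O)c2ccc(Br)cc2)cc1`, is not yet measured. It differs from compound 1 in one place: bromo in place of chloro on an aromatic carbon, that is, (4-chlorophenyl)carbonyl becomes (4-bromophenyl)carbonyl.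

For the measured compounds named here, only one measured step touches a halogen exchange, and it sits on the other ring: no change at the digits printed from compound 1 to compound 3 (within the scatter). That step left the number unchanged within the scatter. The other step, a 10-fold lower number from compound 1 to compound 2 (1.00 log units; beyond the scatter), concerns a nitro group and does not bear on a chloro-to-bromo swap at all. Going by the values given here, no measured pair reports on the halogen of the carbonyl-bearing ring, so the closest guide is the neutral bromo-for-fluoro result from compound 1 to compound 3.

Compound 4 is therefore expected to give 10000 nM, within 4000 nM to 25000 nM, meaning an estimated step of no change at the digits printed from compound 1 to compound 4 (within the scatter), no change beyond the scatter.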

Compound 4, concentration for 50% growth inhibition: 10000 nM
Beside the measured number, compound 4's estimate shows no gap at the digits printed; the range from low to high includes it.
By their numbers in this assay, from the lowest: compound 2; then compounds 1, 3 and 4 (each within the scatter of the next).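

In this assay, for the compounds shown here, the first reading at this position, on the ring of the (4-chlorophenyl)carbonyl group, gives no change at the digits printed from compound 1 to compound 4 (within the scatter) for the exchange of chloro for bromo. The earlier compounds shown here varied only the other aromatic ring, so this step adds that a halogen exchange on the carbonyl-bearing ring also stays within the scatter, as the bromo-for-fluoro exchange did with no change at the digits printed from compound 1 to compound 3 (within the scatter) on the other ring. Nothing available explains this result.

The compounds shown leave open whether an amine or a methoxy group in place of this halogen would move the number, since only chloro and bromo appear here. As far as these compounds go, it also remains open whether bromo at this position would keep the lower number of compound 2, 1000 nM, if combined with that compound's nitro group.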